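Swapping difluoromethyl for methylamino on the shared core

The compounds below may be only part of what the source reports. "The series", "measured", "known", "first", "only" and "open" are said of these compounds alone.

Measured so far in a physicochemical assay for solubility, measured as kinetic solubility (on this read-out higher numbers stand for higher solubility and lower numbers for lower solubility), are these compounds:
- compound 1 `C[C@H](NC(=O)c1cc(C(F)(F)F)nn1C)c1nc(-c2ccnc(N3CCCC3)c2)no1` gives 41000 nM as its value
- compound 2 `C[C@H](NC(=O)c1cc(C(F)(F)F)nn1C)c1nc(-c2ccnc(N(C)C)c2)no1` gives 28000 nM as its value
- compound 3 `C[C@H](NC(=O)c1cc(C(F)(F)F)nn1C)c1nc(-c2ccnc(C(F)F)c2)no1` gives 178000 nM as its value

Compound 3 stands highest of the three, and its steps to both others lie beyond the scatter. The next compound is compound 4 `CNc1cc(-c2noc([C@H](C)NC(=O)c3cc(C(F)(F)F)nn3C)n2)ccn1` which has not yet been measured. It carries methylamino in place of difluoromethyl on an aromatic carbon and the rest of the molecule is unchanged.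

For the measured compounds named here, two measured steps bear on this change, and both arrive at difluoromethyl: a 4.3-fold higher number from compound 1 to compound 3 (0.64 log units; beyond the scatter) and a 6.4-fold higher number from compound 2 to compound 3 (0.80 log units; beyond the scatter) are each modest. Between the two amino-bearing compounds, a 1.5-fold lower number from compound 1 to compound 2 (0.17 log units; within the scatter) shows no separation. Going by the values given here, no compound with methylamino itself has been measured, so the link remains an analogy. Read in reverse, these steps point to a modest fall, with compound 4 expected to sit close to compound 2 at 28000 nM and compound 1 at 41000 nM in this assay terms. The expected step is a 4.7-fold lower number from compound 3 to compound 4 (0.67 log units; beyond the scatter) on this read-out. The estimate for compound 4 is 38000 nM with an expected range from 17000 nM to 85000 nM on this read-out.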

Compound 4, solubility: 143000 nM
For compound 4 the middle estimate is 3.8-fold (0.58 log units) below the measured one, outside the stated range (above it).
By their numbers in this assay, from the lowest: compounds 2 and 1 (each within the scatter of the next); then compounds 4 and 3 (each within the scatter of the next).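

In this assay, for the compounds shown here, placing methylamino on this aromatic carbon next to the ring nitrogen, in place of difluoromethyl, leaves the two groups unseparated (a 1.2-fold lower number from compound 3 to compound 4 (0.10 log units; within the scatter)), whereas difluoromethyl had stood apart from both amino groups among the earlier compounds. Amino groups at this position therefore do not form a single low-value set: hydrogen in place of methyl on the nitrogen gives a clear change (a 5.1-fold higher number from compound 2 to compound 4 (0.71 log units; beyond the scatter)), and methylamino in place of pyrrolidin-1-yl gives one of similar character (a 3.5-fold higher number from compound 1 to compound 4 (0.54 log units; beyond the scatter)), although dimethylamino and pyrrolidin-1-yl themselves lay within the scatter of each other. The compounds shown carry no measurement that would explain this separation among the amino groups.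

From the compounds shown here alone, it remains open where a primary amine or an ethylamino group at this position would fall in this assay, and so whether the value follows the hydrogen on the nitrogen or the size of what is attached there. Going by these compounds, whether replacing methyl with hydrogen on such a nitrogen gives a similar step on any core other than the shared one also remains open.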